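A few compounds are considered here, and "the series" means these few. Any claim that something is new, unique, unknown or untested is made for them only; others in the source may bear on it.

Compounds measured so far:
- compound 1 `Cc1cccc(Cn2c(OC3CCN(C(=O)c4ccco4)CC3)nc3ccccc32)c1`: 68.3%
- compound 2 `Cc1ccccc1Cn1c(CN2CCN(C(=O)C3CC3)CC2)nc2ccccc21`: 29.1%
- compound 3 `Cc1cccc(Cn2c(CN3CCN(C(=O)c4ccc(C(F)(F)F)cc4)CC3)nc3ccccc32)c1`: 22.9%

In an assay on isolated protein for inhibition of aldehyde dehydrogenase 1A1 (Homo sapiens), read by spectrophotometry, tested at 10 uM (a lower number here means less inhibition, a higher number more inhibition at the concentration tested (going by the name of the read-out)), compound 1 gives 68.3% and stands highest of the three measured compounds. Its nearest neighbour is compound 2, which in this assay gives 29.1%, a gap beyond the scatter of the measurement. The furthest is compound 3, which gives 22.9% in this assay, again beyond the scatter. The two lower compounds differ from compound 1 in more than one place, so the gaps cannot be tied to any single change.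

The step now followed leads from compound 1 to compound 4 `CC(C)CCn1c(OC2CCN(C(=O)c3ccco3)CC2)nc2ccccc21`, which has not yet been measured. The change is isobutyl in place of 3-methylphenyl on a saturated chain carbon bound to an aromatic nitrogen. Cut one bond further out, the same difference reads as 3-methylbenzyl giving way to isopentyl.

Among the compounds with values here, no measured pair shows this change on its own, so the expectation rests only on the size of the groups exchanged. A drop beyond the scatter is expected, of about a number 26.3 percentage points lower from compound 1 to compound 4 (beyond the scatter), because compound 1 sits at 68.3% with a larger group at that place. For compound 4 the expected value in this assay is 42%, with a range from 15% to 70%.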

Compound 4, a percentage reported as inhibition, at one concentration (the size of the read-out at that concentration, not a potency): 30.8%
Compound 4: the middle estimate sits 11.2 percentage points above what was measured, within the range that was stated.
By their numbers in this assay, from the lowest: compounds 3, 2 and 4 (each within the scatter of the next); then compound 1.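

Within the data shown here, with the rest of the molecule held the same, the group on a saturated chain carbon bound to an aromatic nitrogen now has a reading of its own in this assay, which the earlier compounds, differing in more than one place, could not give: exchanging 3-methylbenzyl for isopentyl gives a number 37.5 percentage points lower from compound 1 to compound 4 (beyond the scatter). This place is therefore not indifferent to what it carries, since 3-methylphenyl, with its six-membered aromatic ring and 7 heavy atoms, cannot be exchanged for isobutyl, with no ring and 4 heavy atoms, without a loss of inhibition at the concentration tested. Nothing measured here says why the inhibition falls with this change.

This single step changes the ring and the number of heavy atoms together, so it leaves open which of the two matters; a cyclohexylmethyl group at this place, with a saturated ring of carbon, would begin to separate them. Also open, going by these compounds, is what the methyl on the ring contributes, which a plain benzyl group would address, and whether a longer chain without a ring would behave like isopentyl.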